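The source may hold more compounds than are shown below. What is called first, only, known or untested is meant among the compounds shown, and "the series" means these compounds.

Within the data shown here, in a functional assay on PC-3 cells (Homo sapiens) for inhibition, read by MTT assay, with stated times of 18 h and 4 h (on this read-out lower numbers stand for stronger inhibition and higher numbers for weaker inhibition), compound 2 `CCCCCCCCCCCCCCCCOP(=O)(O)OCCSC(=S)N1CCN(C)CC1` gives 95200 nM, the only actual number available so far. Compound 1 `CCCCCCCCOP(=O)(O)OCCSC(=S)N1CCCCC1` gives > 100000 nM, which is a limit of the assay and not a number. Compound 3 `CCCCCCCCOP(=O)(O)OCCSC(=S)N1CCN(C)CC1` has not yet been measured. It differs from compound 2 in one place: hydrogen in place of octyl on a saturated chain carbon, eight bonds along the chain from an oxygen on an unsaturated carbon. Hydrogen stands in place of octyl on a saturated chain carbon, eight bonds along the chain from an oxygen on an unsaturated carbon, so the long chain is cut short. Compound 3 shares this shorter chain with compound 1, which reached only the limit of > 100000 nM, although compound 1 also differs elsewhere. The expected step of a 1.4-fold higher number from compound 2 to compound 3 (0.14 log units; within the scatter) is small, towards weaker inhibition and within the usual scatter. The estimate for compound 3 is 130000 nM, with an expected range from 70000 nM to 260000 nM, and this assay may well report only a limit.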

Compound 3, half-maximal inhibitory concentration: > 100000 nM
Compound 3 ended at the assay's limit (the forecaster's own chance of this, stated with the estimate: 65%); the middle value lies beyond the limit too.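

In this assay, putting hydrogen in place of octyl on this saturated chain carbon gives an at least 1.0-fold higher number from compound 2 to compound 3 (0.02 log units; that floor lies within the scatter), and that figure is only a floor for the step. Compound 3 gives > 100000 nM, which is a limit and not a number, so the true size of this step stays hidden, and the step from piperidin-1-yl to 4-methylpiperazin-1-yl cannot be read either. The shorter chain on the 4-methylpiperazin-1-yl compound shows no sign of stronger inhibition, but little more can be said, because most of the values stop at the same ceiling: the limit of > 100000 nM in this assay, at which 2 of the 3 values shown sit.

From the compounds shown here alone, it remains open how a dodecyl chain on the same core would behave. Also open, going by these compounds, is whether a morpholin-4-yl group on the thiocarbonyl carbon would bring a readable number.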